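A few compounds are considered here, and "the series" means these few. Any claim that something is new, unique, unknown or untested is made for them only; others in the source may bear on it.

Compound 1, `Cc1ccnc(/C(N)=N/NC(=S)N2CCSCC2)c1`, in a functional assay on A-431 cells (Homo sapiens) for cytotoxicity, read by MTT assay, with a stated time of 72 h; a higher number here means a weaker inhibitor, a lower number a stronger inhibitor: 7200 nM.
Compound 2, `Cc1ccnc(/C(N)=N/NC(=S)N2CCCC2)c1`, in this assay: 900 nM.
Compound 3, `N/C(=N\NC(=S)N1CCN(c2ccccn2)CC1)c1ccc(F)cn1`, in this assay: 13400 nM.

Compound 3 has the highest number of the three; its gap to compound 1 lies within the scatter, while compound 2 sits well below it. Going by the values given here, the only measured step, an 8.0-fold lower number from compound 1 to compound 2 (0.90 log units; beyond the scatter), concerns the group on the thiocarbonyl carbon and leaves the aromatic ring untouched. Compound 4, `N/C(=N\NC(=S)N1CCN(c2ccccn2)CC1)c1ccccn1`, arises from compound 3 by hydrogen in place of fluoro on an aromatic carbon. Among the compounds with values here, no measured step touches this position, so nothing argues for a shift beyond the scatter in this assay in either direction. The expected step is a 1.1-fold lower number from compound 3 to compound 4 (0.05 log units; within the scatter), and compound 4 is estimated at 12000 nM, in a range from 5000 nM to 30000 nM.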

Compound 4, half-maximal inhibitory concentration: 4300 nM
Compound 4: middle estimate off by 2.8-fold (0.45 log units), on the high side; the measured number lies below the stated range.
By their numbers in this assay, from the lowest: compound 2; then compounds 4, 1 and 3 (each within the scatter of the next, the first and the last beyond it).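

In this assay, going by these compounds alone, the change from 5-fluoropyridin-2-yl to pyridin-2-yl gives a 3.1-fold lower number from compound 3 to compound 4 (0.49 log units; beyond the scatter) and is the first measured step at this aromatic carbon. It shows that the number responds to this single atom change, with the rest of compound 3 held fixed. No available evidence explains this shift.

Going by these compounds, whether chloro, methoxy or an amine at this carbon would move the number in the same direction remains open. So does whether the step would carry over to a compound bearing the pyrrolidin-1-yl group of compound 2.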